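Shifting the hydroxyl on the pendant phenyl ring

This account rests on a few compounds, and the source may have more. Where it says the series, first, only, none or still open, it means among the compounds named here.

Three analogues on one shared core were compared in an assay for inhibition of Maternal embryonic leucine zipper kinase (Homo sapiens), read by ADP-Glo, with a stated time of 0.5 h; on this read-out lower numbers stand for stronger inhibition and higher numbers for weaker inhibition. Compound 1 `CC(C)Nc1sc(C(=O)c2ccc(Cl)s2)c(N)c1C#N` gives 192 nM. Compound 2 `CC(C)Nc1sc(C(=O)c2ccc(I)s2)c(N)c1C#N` gives 112 nM, and a 1.7-fold lower number from compound 1 to compound 2 (0.23 log units; within the scatter). Compound 3 `CC(C)Nc1sc(C(=O)c2ccc(-c3ccc(O)cc3)s2)c(N)c1C#N` gives 241 nM, the highest of the three numbers: a 1.3-fold higher number from compound 1 to compound 3 (0.10 log units; within the scatter), while a 2.2-fold higher number from compound 2 to compound 3 (0.33 log units; beyond the scatter). Compound 4 `CC(C)Nc1sc(C(=O)c2ccc(-c3cccc(O)c3)s2)c(N)c1C#N` has not yet been measured; in it (3-hydroxyphenyl in place of 4-hydroxyphenyl on an aromatic carbon). Going by the values given here, no measured step moves the hydroxyl around that ring. The measured steps show only that exchanging the halogen for the 4-hydroxyphenyl group altered the number little, as in a 1.3-fold higher number from compound 1 to compound 3 (0.10 log units; within the scatter). The expected step is therefore small, a 1.0-fold lower number from compound 3 to compound 4 (0.00 log units; within the scatter). Compound 4 is estimated at 240 nM, with a range from 110 nM to 520 nM.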

Compound 4, half-maximal inhibitory concentration: 350 nM
Compound 4: middle estimate off by 1.5-fold (0.16 log units), on the low side; the range from low to high includes it.
By their numbers in this assay, from the lowest: compounds 2, 1, 3 and 4 (each within the scatter of the next, the first and the last beyond it).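

In this assay, the first measured move of the hydroxyl around the pendant phenyl ring, from 4-hydroxyphenyl to 3-hydroxyphenyl, stays within the scatter (a 1.5-fold higher number from compound 3 to compound 4 (0.16 log units; within the scatter)). The 3-hydroxyphenyl group, like the 4-hydroxyphenyl group, stands apart from iodo (a 3.1-fold higher number from compound 2 to compound 4 (0.49 log units; beyond the scatter)) but not from chloro (a 1.8-fold higher number from compound 1 to compound 4 (0.26 log units; within the scatter)). Nothing available explains these numbers.

Going by these compounds, whether an amine or a carboxylic acid in place of the hydroxyl on that ring would keep the number in this range remains open.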